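Cyclopropyl for Methyl: An Expected Step in Inhibition

This account rests on a few compounds, and the source may have more. Where it says the series, first, only, none or still open, it means among the compounds named here.

Measured so far:
Compound 1 `CC1c2cc(Cl)ccc2C(=O)N1c1cccnc1`: 1250 nM
Compound 2 `CC(=O)N[C@@H]1CCCc2c1cncc2N1C(=O)c2ccc(Cl)cc2[C@H]1C`: 5140 nM
Compound 3 `CC(=O)N[C@@H]1CCCc2c1cncc2N1C(=O)c2ccc(Cl)cc2[C@H]1C1CC1`: 22800 nM

All three were tested in an ADME assay on cells for inhibition of cytochrome P450 11B1, mitochondrial (Homo sapiens), read by HTRF; on this read-out higher numbers stand for weaker inhibition and lower numbers for stronger inhibition. Compound 1 gives 1250 nM, the lowest of the three numbers. Compound 2 and compound 3 share a core that is not the core of compound 1; the difference between the two cores is not broken down here. From compound 2 to compound 3 the change is cyclopropyl in place of methyl on a saturated ring carbon, and it brings a 4.4-fold higher number from compound 2 to compound 3 (0.65 log units; beyond the scatter).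

Compound 4 `O=C1c2ccc(Cl)cc2C(C2CC2)N1c1cccnc1` has not yet been measured. It arises from compound 1 by cyclopropyl in place of methyl on a saturated ring carbon. This is the same kind of change as in the measured pair, though the surroundings are described differently: in compound 2 the place is next to the ring atom that bears a large group, while in compound 1 it is next to the ring atom that bears a pyridin-3-yl group (6 heavy atoms).

The expectation rests on compound 2 and compound 3 and their step of a 4.4-fold higher number from compound 2 to compound 3 (0.65 log units; beyond the scatter). For compound 4 the expected step is a 4.0-fold higher number from compound 1 to compound 4 (0.60 log units; beyond the scatter). Compound 4 is therefore estimated at 5000 nM, with a likely range from 2000 nM to 14000 nM.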

Compound 4, half-maximal inhibitory concentration: 32500 nM
Compound 4: the middle estimate sits 6.5-fold (0.81 log units) below what was measured, outside the stated range (above it).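

In this assay, cyclopropyl in place of methyl gives a higher number, meaning weaker inhibition, on both cores, and on the core of compound 1 the step is a 26-fold higher number from compound 1 to compound 4 (1.41 log units; beyond the scatter). The direction of the change carries over from one core to the other, but its size does not: the same change on two cores in this assay, a 4.4-fold higher number (0.65 log units; beyond the scatter) from compound 2 to compound 3 and a 26-fold higher number (1.41 log units; beyond the scatter) from compound 1 to compound 4, 5.9-fold (0.77 log units) apart, beyond the scatter of two such steps. Two pairs show that a step measured on one core in this series can point the way on another core without fixing how large the step will be, but they do not show why the two steps differ or how the change would behave on any further core.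

The compounds shown leave open how an ethyl group, an isopropyl group or a hydroxymethyl group on the same saturated ring carbon would read on each core. They also leave open which part of the two cores goes with the difference in step size.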